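Flipping one stereocentre in a phenylethyl urea

The source may report more compounds than this note shows. Statements on the series, on what has been measured and on what is new or still open speak of the compounds shown alone.

Compound 2, `C[C@@H](NC(=O)Nc1ccccc1Br)c1ccccc1`, is one of two ureas measured in an ADME assay on the whole organism with Oryza sativa as the target, tested at 1 uM; on this read-out lower numbers stand for a stronger effect and higher numbers for a weaker effect at the one concentration tested. In this assay compound 2 gives 100%, while compound 1, `C[C@H](NC(=O)Nc1ccccc1Cl)c1ccccc1`, gives 104%; these two values lie within the usual scatter of each other, and both sit near full activity, meaning little effect. Compound 3, `C[C@H](NC(=O)Nc1ccccc1Br)c1ccccc1`, is not yet measured. It differs from compound 2 only in configuration: the two compounds have the same atoms and bonds and differ only in configuration as drawn: 1 of 1 stereo elements differ; a stereocentre at a saturated chain carbon is drawn R in compound 2 and S in compound 3. Because compound 1 with the opposite configuration gives 104%, no step beyond the scatter is expected, so a number 1 percentage points higher from compound 2 to compound 3 (within the scatter) is the estimated change. Compound 3 is thus expected to give 101%, within 90% to 112%.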

Compound 3, a percentage reported as activity, at one concentration (the size of the read-out at that concentration, not a potency): 99%
Compound 3: middle estimate off by 2 percentage points, on the high side; measured number inside the range.
By their numbers in this assay, from the lowest: compounds 3, 2 and 1 (each within the scatter of the next).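

In this assay, turning the stereocentre from R to S gives a number 1 percentage points lower from compound 2 to compound 3 (within the scatter), so this pair shows no effect of configuration beyond the scatter. With the S configuration held, the halogen swap gives a number 5 percentage points lower from compound 1 to compound 3 (within the scatter), so bromo and chloro are not told apart here either. The first comparison isolates the stereocentre alone: the fact that compounds 2 and 3 differ only in the configuration as drawn

All three compounds carry a halogen on the aromatic ring and stay near full activity. On these data alone, whether an amine or a carboxylic acid in place of that halogen, or a longer chain in place of the methyl group, would move the number remains open.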